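Replacing quinolin-6-yl on the shared core: notes on compound 3

This account rests on a few compounds, and the source may have more. Where it says the series, first, only, none or still open, it means among the compounds named here.

Of the compounds shown here, two have been measured so far. In a functional assay on MDA-MB-231 cells (Homo sapiens) for antiproliferative activity, with a stated time of 5 days (a lower number here means a stronger inhibitor, a higher number a weaker inhibitor), compound 1 `O=C1C=CC2(C=C1)OCC(=O)N2c1nc(-c2ccc3ncccc3c2)nn1-c1ccccc1` gives 50 nM and compound 2 `O=C1C=CC2(C=C1)OCC(=O)N2c1nc(-c2ccc3ccccc3c2)nn1-c1ccc2ccccc2c1` gives 50 nM, so the two stand level at the digits shown. Compound 3 `O=C1C=CC2(C=C1)OCC(=O)N2c1nc(-c2cccc(Cl)c2)nn1-c1ccccc1` has not yet been measured. It carries 3-chlorophenyl in place of quinolin-6-yl on an aromatic carbon of a five-membered aromatic ring with 3 nitrogen (3-chlorophenyl in place of quinolin-6-yl on an aromatic carbon). The other groups on the core of compound 1 stay the same. Within the data shown here, no measured pair isolates a change at this carbon, so the data offer no direct guide. A moderate weakening in this assay is expected, with little confidence in its size and no firm exclusion of a result within the scatter. The estimated change is a 3.0-fold higher number from compound 1 to compound 3 (0.48 log units; beyond the scatter). For compound 3, the estimated value is 150 nM, with an expected range of 40 nM to 600 nM.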

Compound 3, half-maximal inhibitory concentration: 0.8 nM
Compound 3: the middle estimate sits 190-fold (2.27 log units) above what was measured; measured number below the stated range.
By their numbers in this assay, from the lowest: compound 3; then compounds 1 and 2 (each within the scatter of the next).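

In this assay, among these compounds, 3-chlorophenyl in place of quinolin-6-yl gives a 63-fold lower number from compound 1 to compound 3 (1.80 log units; beyond the scatter), so this aromatic carbon, which no earlier pair isolated, is a position where a single change moves the number well beyond the scatter. The step also shows that quinolin-6-yl is not required for a low number here: the entering group has one aromatic ring, fewer heavy atoms and no hydrogen-bond acceptor. No available measurement explains the size of this step.

From the compounds shown here alone, this single step cannot separate the loss of quinolin-6-yl from the arrival of chlorine, so it remains open whether plain phenyl, or a methoxy group or nitrile in place of the chlorine, would keep this level. Going by these compounds, it is also open whether 3-chlorophenyl gives a similar step with other groups on the shared core.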